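This account rests on a few compounds, and the source may have more. Where it says the series, first, only, none or still open, it means among the compounds named here.

Compound 3 `CCNC(=O)Nc1ccc(S(=O)(=O)Nc2ccccc2C)cc1` is one of three close relatives examined here. In a functional assay on M21 cells (Homo sapiens) for cytotoxicity, read by sulforhodamine B assay, with a stated time of 48 h (on this read-out lower numbers stand for stronger inhibition and higher numbers for weaker inhibition), compound 3 gives only a limit, > 200000 nM. Compound 1 `Cc1ccccc1NS(=O)(=O)c1ccc(NC(=O)NCCCCl)cc1` also gives only a limit in this assay, > 200000 nM. Compound 2 `CCNC(=O)Nc1ccc(S(=O)(=O)Oc2ccc(O)cc2)cc1` gives a measurable number in this assay, 4300 nM. Within the data shown here, the single one-place step among the measured compounds, a step that the two limits leave unreadable from compound 1 to compound 3, cannot be sized because both ends sit at the limit of > 200000 nM in this assay, at which 2 of the 3 values shown sit. Among the measured compounds shown here, compound 4 `CCCc1ccccc1NS(=O)(=O)c1ccc(NC(=O)NCC)cc1` differs from compound 3 by ethyl in place of hydrogen on a saturated chain carbon bound to an aromatic carbon; no measured step touches this kind of change, so no movement beyond the scatter is expected from it. For compound 4 the expected result is an estimated 200000 nM with a range from 50000 nM to 1000000 nM, an estimated step of a number no higher from compound 3 to compound 4 (the limit leaves the size open).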

Compound 4, half-maximal inhibitory concentration: 41000 nM
Beside the measured number, compound 4's estimate is 4.9-fold (0.69 log units) above it; measured number below the stated range.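

In this assay, going from methyl to propyl on a saturated chain carbon bound to an aromatic carbon gives an at least 4.8-fold lower number from compound 3 to compound 4 (0.68 log units; beyond the scatter). Among these compounds, this shows that the place can move the number beyond the scatter, which no earlier step could show. The full size stays open because compound 3 gives only a limit: the limit of > 200000 nM in this assay, at which 2 of the 4 values shown sit.

As far as these compounds go, whether a butyl chain would lower the number further remains open. So does the effect of an amine or a carboxylic acid at the end of this chain.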